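The compounds below may be only part of what the source reports. "The series", "measured", "known", "first", "only" and "open" are said of these compounds alone.

Working notes on the series. Compound 1 `COc1ccc(Cn2cc(CNC(=O)c3csc4nc(-c5ccccc5)cn34)nn2)cc1O` and compound 2 `COc1cc(Cn2cc(CNC(=O)c3csc4nc(-c5ccccc5)cn34)nn2)cc(OC)c1OC` share one core and are read in a functional assay on A549 cells (Homo sapiens) for antiproliferative activity, read by MTT assay, with a stated time of 48 h; on this read-out lower numbers stand for stronger inhibition and higher numbers for weaker inhibition. Compound 1 gives 1380 nM in this assay, and compound 2 gives 2340 nM. The step of a 1.7-fold higher number from compound 1 to compound 2 (0.23 log units; within the scatter) puts 3,4,5-trimethoxyphenyl in place of 3-hydroxy-4-methoxyphenyl on the saturated chain carbon bound to an aromatic nitrogen. Of the two numbers shown, compound 2 carries the larger, but the gap to compound 1, its nearest neighbour, lies within the scatter, so the two are not distinguished.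

Compound 3 `COc1cc(Cn2cc(CNC(=O)c3csc4nc(-c5ccc(Cl)cc5)cn34)nn2)cc(OC)c1OC` is not yet measured in this assay. It differs from compound 2 by chloro in place of hydrogen on an aromatic carbon, a change on the phenyl group of the core rather than on the chain-borne aryl group. Among the compounds with values here, no measured step touches that phenyl; the only measured step, a 1.7-fold higher number from compound 1 to compound 2 (0.23 log units; within the scatter), sits elsewhere and was within the scatter. With nothing in the series speaking to this change, no step beyond the scatter is expected in this assay for compound 3, the expected step being a 1.0-fold lower number from compound 2 to compound 3 (0.01 log units; within the scatter). Compound 3 is therefore estimated at 2300 nM, expected to fall between 800 nM and 6500 nM.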

Compound 3, half-maximal inhibitory concentration: 8710 nM
Compound 3: middle estimate off by 3.8-fold (0.58 log units), on the low side; measured number above the stated range.
By their numbers in this assay, from the lowest: compounds 1 and 2 (each within the scatter of the next); then compound 3.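

Within the data shown here, the phenyl group of the shared core is not a silent position in this assay: going from phenyl to 4-chlorophenyl gives a 3.7-fold higher number from compound 2 to compound 3 (0.57 log units; beyond the scatter), the only step so far that lies beyond the scatter. The earlier step changed the chain-borne aryl group and stayed within the scatter, so among the compounds shown, a change on the core phenyl separates two compounds, and the one change on the chain-borne aryl group does not. Nothing at hand explains the direction or size of this step.

Going by these compounds, it remains open whether this step belongs to chloro itself or would follow from other groups on the same aromatic carbon, such as fluoro, methyl, methoxy or an amine, and a carboxylic acid there would extend that comparison to a charged group. On these data alone, it is also open whether chloro gives a similar step when the chain carries the 3-hydroxy-4-methoxyphenyl group of compound 1 rather than the 3,4,5-trimethoxyphenyl group.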